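A few compounds are considered here, and "the series" means these few. Any claim that something is new, unique, unknown or untested is made for them only; others in the source may bear on it.

Series notes. The three measured compounds share one core and differ only in what sits on the amide-type nitrogen. Compound 1 `Cc1cc(C(=O)N2CCCCc3ccccc32)ccc1CNC(=O)Nc1c(F)cccc1F` gives 2.1 nM in a functional assay on HEK293 cells for agonist activity at Vasopressin V2 receptor (Homo sapiens), read by a luciferase reporter and cAMP accumulation; on this read-out higher numbers stand for an effect only at larger amounts of compound and lower numbers for an effect already at smaller amounts. Compound 2 `Cc1cc(C(=O)N2CCCCc3ccccc32)ccc1CNC(=O)Nc1ccccc1F` gives 30 nM in this assay, and compound 3 `Cc1cc(C(=O)N2CCCCc3ccccc32)ccc1CNC(=O)NCC(=O)O` gives 180 nM. Compound 2 stands second highest of the three numbers: its nearest neighbour is compound 3, reached by a 6.0-fold higher number from compound 2 to compound 3 (0.78 log units; beyond the scatter), and its furthest is compound 1, from which there is a 14-fold higher number from compound 1 to compound 2 (1.15 log units; beyond the scatter).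

Compound 4 `Cc1cc(C(=O)N2CCCCc3ccccc32)ccc1CNC(=O)NCC(=O)N(C)C` is not yet measured. It differs from compound 2 by (dimethylcarbamoyl)methyl in place of 2-fluorophenyl on an amide-type nitrogen. The measured step that bears most directly on this change is a 6.0-fold higher number from compound 2 to compound 3 (0.78 log units; beyond the scatter), where the 2-fluorophenyl was likewise exchanged for a group with no ring; an 86-fold higher number from compound 1 to compound 3 (1.93 log units; beyond the scatter) points the same way from the stronger end. Among the measured compounds shown here, no measured pair sets the carboxymethyl against the (dimethylcarbamoyl)methyl, so how compound 3 and compound 4 relate is open. Because a 6.0-fold higher number from compound 2 to compound 3 (0.78 log units; beyond the scatter) went upward, the step expected for compound 4 is a 5.0-fold higher number from compound 2 to compound 4 (0.70 log units; beyond the scatter), a modest rise in the number. For compound 4 the estimate is 150 nM, within 40 nM to 600 nM.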

Compound 4, half-maximal effective concentration: 58 nM
The estimate for compound 4 lay 2.6-fold (0.41 log units) above the measured number, and the stated range covers the measured number.
By their numbers in this assay, from the lowest: compound 1; then compounds 2 and 4 (each within the scatter of the next); then compound 3.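

On the amide-type nitrogen, the ring is not needed to hold the level of compound 2 in this assay: (dimethylcarbamoyl)methyl in place of 2-fluorophenyl gives a 1.9-fold higher number from compound 2 to compound 4 (0.29 log units; within the scatter) and so cannot be told apart from the ring-bearing group, which compound 3 alone could not have shown. The end of the ring-free chain counts, since dimethylamino in place of hydroxy on the carbonyl carbon gives a 3.1-fold lower number from compound 3 to compound 4 (0.49 log units; beyond the scatter) and the carboxymethyl result therefore does not hold for every group without a ring. The 2,6-difluorophenyl group still stands apart, with a 28-fold higher number from compound 1 to compound 4 (1.44 log units; beyond the scatter) in this series, so compound 4 reaches the level of compound 2 but not that of compound 1.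

No measurement at hand gives a reason for any of these steps. Open, from the compounds shown here alone, is where a methyl ester, a primary carboxamide, a longer chain before the carbonyl or a chain ending in an amine would fall relative to compound 3 and compound 4, and whether any ring-free group can match the 2,6-difluorophenyl group.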